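This account rests on a few compounds, and the source may have more. Where it says the series, first, only, none or still open, it means among the compounds named here.

In an assay on Sf9 cells for inhibition of protein deacetylase HDAC6 (Homo sapiens), read by fluorescence, with a stated time of 40 min, tested at 100 nM (on this read-out higher numbers stand for more inhibition at the one concentration tested (going by the name of the read-out) and lower numbers for less inhibition), three compounds have been measured. Compound 1 `Cc1cccc(-c2nc(CNc3ccc(C(=O)NO)cc3)n(-c3ccccc3)n2)c1` gives 64.1%, compound 2 `O=C(NO)c1ccc(NCc2nc(-c3ccccc3)nn2-c2ccccc2Cl)cc1` gives 64.6%, and compound 3 `Cc1ccc(-n2nc(-c3ccccc3)nc2CNc2ccc(C(=O)NO)cc2)cc1` gives 60.7%. Compound 1 stands second highest of the three numbers, nearest to compound 2 and furthest from compound 3, both gaps within the scatter. Among the compounds with values here, the only step among them, a number 3.9 percentage points lower from compound 2 to compound 3 (within the scatter), concerns 4-methylphenyl in place of 2-chlorophenyl on an aromatic nitrogen. Compound 4 `O=C(NO)c1ccc(NCc2nc(-c3ccc(F)cc3)nn2-c2ccccc2)cc1` differs from compound 1 by 4-fluorophenyl in place of 3-methylphenyl on an aromatic carbon. Within the data shown here, no measured step touches this aromatic carbon, and the one step that exists stays within the scatter, so no move beyond the scatter is expected. Compound 4 is therefore estimated at 62%, from 50% to 74%, an expected step of a number 2.1 percentage points lower from compound 1 to compound 4 (within the scatter).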

Compound 4, a percentage reported as inhibition, at one concentration (the size of the read-out at that concentration, not a potency): 70.9%
Compound 4: the middle estimate sits 8.9 percentage points below what was measured; measured number inside the range.
By their numbers in this assay, from the lowest: compounds 3, 1, 2 and 4 (each within the scatter of the next, the first and the last beyond it).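

In this assay, this aromatic carbon of the five-membered ring now has a measured step of its own: 4-fluorophenyl in place of 3-methylphenyl gives a number 6.8 percentage points higher from compound 1 to compound 4 (within the scatter). The two groups match in heavy-atom count and both carry no hydrogen-bond donors or acceptors, and the number for this exchange at this position stays level within the scatter. No evidence is at hand on why the number moves. The compounds shown leave open whether the fluorine or the changed ring position accounts for the step. They also leave open whether a carboxylic acid or an amine on this carbon would move the number beyond the scatter.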